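The compounds below may be only part of what the source reports. "The series", "measured", "known", "first", "only" and "open" are said of these compounds alone.

Working notes on the series.

Of the compounds shown here, two of the shared core have been measured in a functional assay on U-251 cells (Homo sapiens) for cytotoxicity, read by resazurin assay, with a stated time of 48 h; a higher number here means a weaker inhibitor, a lower number a stronger inhibitor. Compound 1 `CC(C)(C)c1cc2[nH]c(C(C)(C)C)cc(=O)n2n1` gives 941000 nM in this assay. Compound 2 `Cc1cc2[nH]c(-c3ccccc3)cc(=O)n2n1` gives 293000 nM in this assay. Of the two numbers, that of compound 2 is the lower one, and the gap to compound 1 lies beyond the scatter; compound 1 and compound 2 differ in more than one place, so the two values are taken as they stand and no single change is read from them.

Compound 3 `Cc1ccc(-c2cc3[nH]c(-c4ccccc4)cc(=O)n3n2)cc1` is not yet measured. It differs from compound 2 by 4-methylphenyl in place of methyl on an aromatic carbon. Within the data shown here, no measured pair shows this change, so its effect on this assay is open. Among the measured compounds shown here, the working expectation is a modest step in this assay, towards a lower number, of about a 2.0-fold lower number from compound 2 to compound 3 (0.29 log units; within the scatter), since the series so far offers no measured step to anchor it. On that basis compound 3 is estimated at 150000 nM in this assay, with a range from 50000 nM to 450000 nM.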

Compound 3, half-maximal inhibitory concentration: 148000 nM
Estimate against measurement, compound 3: 1.0-fold (0.01 log units) above, within the range that was stated.
By their numbers in this assay, from the lowest: compounds 3 and 2 (each within the scatter of the next); then compound 1.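

The series now holds its first step in one place: in this assay the step is a 2.0-fold lower number from compound 2 to compound 3 (0.30 log units; within the scatter) for 4-methylphenyl in place of methyl on an aromatic carbon, and it lies within the scatter, so compound 2 and compound 3 are not told apart. At this carbon of the five-membered aromatic ring, then, the methyl of compound 2 can give way to a group carrying a six-membered aromatic ring of carbon only, with no shift beyond the scatter in this read-out. Nothing at hand explains why the number stays where it does, and no supporting measurement bears on this step.

Still open, as far as these compounds go, is whether any group at this carbon can move the number beyond the scatter: an unsubstituted phenyl would show what the methyl of the 4-methylphenyl contributes, while an amine, a carboxylic acid or a longer alkyl chain would test groups of a different kind. The phenyl on the other side of the core also remains without a single-place step, so its contribution in this assay cannot be read from these compounds.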